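Methoxycarbonyl for Methoxy on a Pyrazole Oxime Ether Pair

The source may hold more compounds than are shown below. What is called first, only, known or untested is meant among the compounds shown, and "the series" means these compounds.

Compound 1 `COc1ccc(CO/N=C/c2c(C)nn(C)c2Oc2ccc(Cl)cc2)cc1` is one of two measured compounds in this set. In a functional assay on HepG2 cells (Homo sapiens) for antiproliferative activity, tested at 1 uM (on this read-out lower numbers stand for less inhibition and higher numbers for more inhibition at the one concentration tested (going by the name of the read-out)), compound 1 gives 13.9%. Its only companion, compound 2 `COc1cccc(CO/N=C/c2c(C)nn(C)c2Oc2ccccc2)c1`, in this assay gives -41.2%, a value that lies well below that of compound 1; the two differ in more than one place, so their values can only be set side by side. Compound 1 thus holds the higher of the two numbers, and the gap between them lies beyond the usual scatter.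

Compound 3 `COC(=O)c1ccc(CO/N=C/c2c(C)nn(C)c2Oc2ccc(Cl)cc2)cc1` has not yet been measured. It differs from compound 1 by methoxycarbonyl in place of methoxy on an aromatic carbon. Among the compounds with values here, no step between two measured compounds shows what such a change does here. The account therefore expects the step of a number 3.9 percentage points lower from compound 1 to compound 3 (within the scatter) to be small and not beyond the scatter. Compound 3 is estimated to give 10%, with a range from -25% to 40%.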

Compound 3, a percentage reported as inhibition, at one concentration (the size of the read-out at that concentration, not a potency): 20.3%
Beside the measured number, compound 3's estimate is 10.3 percentage points below it; measured number inside the range.
By their numbers in this assay, from the lowest: compound 2; then compounds 1 and 3 (each within the scatter of the next).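

In this assay, within the data shown here, the first direct reading of a single change at this position is a number 6.4 percentage points higher from compound 1 to compound 3 (within the scatter) for methoxycarbonyl in place of methoxy, on an aromatic carbon para to a large group. The earlier pair differed in more than one place and could not show this; here the larger group, with its added carbonyl and second hydrogen-bond acceptor, leaves the read-out within the scatter of the methoxy compound. No measurement at hand bears on why the two compounds read so closely.

The compounds shown leave open whether a carboxylic acid, an amine or a longer chain on this same aromatic carbon would stay within that scatter or move beyond it. They also leave open whether methoxycarbonyl would behave in the same way on a core without the chlorine of compound 1.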